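A few compounds are considered here, and "the series" means these few. Any claim that something is new, unique, unknown or untested is made for them only; others in the source may bear on it.

Working notes on the series, continued at compound 4.

The shared core is carried unchanged through compounds 1 to 3; they differ only in the group on the saturated chain carbon bound to the ring amide nitrogen. Compound 1 `Cc1noc(-c2nc(C)c3c(c2N)C(=O)N(Cc2ccc(-c4ccncc4)cc2)C3=O)n1` is measured in a physicochemical assay for solubility, using the shake flask method, in simulated intestinal fluid, measured as kinetic solubility, with a stated time of 2 h, at 25 degrees C, at pH 6.5 (on this read-out higher numbers stand for higher solubility and lower numbers for lower solubility), and gives only a limit of the assay, < 5000 nM. Compound 2 `Cc1noc(-c2nc(C)c3c(c2N)C(=O)N(Cc2ccc(Oc4ccc(F)cc4)cc2)C3=O)n1` gives 23800 nM in this assay. Compound 3 `COc1ccc(CN2C(=O)c3c(C)nc(-c4nc(C)no4)c(N)c3C2=O)cc1` likewise gives only a limit, < 5000 nM in this assay. So compound 3 stands at the lower edge of what the assay reports, as does compound 1 (the limit of < 5000 nM in this assay, at which 2 of the 3 values shown sit), with compound 2 the only numbered value: an at least 4.7-fold higher number from compound 1 to compound 2 (0.67 log units; beyond the scatter) and an at least 4.7-fold lower number from compound 2 to compound 3 (0.67 log units; beyond the scatter), while a step that the two limits leave unreadable from compound 1 to compound 3.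

Compound 4 `Cc1noc(-c2nc(C)c3c(c2N)C(=O)N(Cc2ccncc2)C3=O)n1` has not yet been measured in this assay. The change from compound 3 is pyridin-4-yl in place of 4-methoxyphenyl on a saturated chain carbon bound to an amide-type nitrogen in a ring. Going by the values given here, no measured step covers this change directly; the nearest comparison, between compound 1 and compound 3, puts pyridin-4-yl and methoxy on the same aromatic carbon and leaves both at the limit, so no direction can be read from it. The expectation for compound 4 is therefore a step from compound 3 that cannot be placed beyond the scatter, a number no lower from compound 3 to compound 4 (the limit leaves the size open), with a fair chance that the assay again returns only a limit. The estimated value for compound 4 in this assay is 5000 nM, in the range 1500 nM to 15000 nM.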

Compound 4, solubility: 26400 nM
For compound 4 the middle estimate is 5.3-fold (0.72 log units) below the measured one; the whole stated range lies below it.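

Pyridin-4-yl in place of 4-methoxyphenyl on a saturated chain carbon bound to an amide-type nitrogen in a ring gives, in this assay, an at least 5.2-fold higher number from compound 3 to compound 4 (0.72 log units; beyond the scatter), the first readable step in which the ring on that carbon is itself exchanged rather than only the group it carries. Until now pyridin-4-yl stood only as an outer group on the benzyl ring, and there compound 1 gives < 5000 nM, which is a limit, whereas in compound 4 the same ring on the chain carbon yields a numbered value. The step starts from the limit of compound 3, so only its lower bound can be read and its full size stays open: the limit of < 5000 nM in this assay, at which 2 of the 4 values shown sit.

The compounds shown cannot separate the ring nitrogen of pyridin-4-yl from the loss of the methoxy group, a question that a plain benzyl group on the ring amide nitrogen would address. From the compounds shown here alone, how a pyridin-3-yl ring, a morpholine or a longer chain in place of the saturated chain carbon would read in this assay also remains open.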